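From Compound 2 to Compound 3: One Group Exchanged

This account rests on a few compounds, and the source may have more. Where it says the series, first, only, none or still open, it means among the compounds named here.

In a functional assay on KYSE-450 cells (Homo sapiens) for inhibition, read by CCK-8 assay, with a stated time of 48 h (a higher number here means a weaker inhibitor, a lower number a stronger inhibitor), compound 1 (`COc1ccc(CN(C(=O)CSC(=S)N2CCOCC2)c2cc(OC)c(OC)c(OC)c2)cc1`) gives 7220 nM and compound 2 (`COc1ccc(CN(C(=O)CSC(=S)N2CCc3cc(OC)ccc32)c2cc(OC)c(OC)c(OC)c2)cc1`) gives 10200 nM. For the measured compounds named here, the two values cannot be told apart, so compound 2 stands level with compound 1 on the only numbers available. Compound 3 (`COc1ccc(CN(C(=O)CSC(=S)N2CCCc3cc(C)ccc32)c2cc(OC)c(OC)c(OC)c2)cc1`) keeps the shared core and differs from compound 2 only on a thiocarbonyl carbon, with 6-methyl-1,2,3,4-tetrahydroquinolin-1-yl in place of 5-methoxy-2,3-dihydro-1H-indol-1-yl on a thiocarbonyl carbon. Going by the values given here, the one measured exchange at this place is a 1.4-fold higher number from compound 1 to compound 2 (0.15 log units; within the scatter). Among the compounds with values here, that single step, made with a different group, is the only guide, and it gives no reason to expect a change beyond the scatter in this assay. The expected step is a 1.2-fold lower number from compound 2 to compound 3 (0.08 log units; within the scatter), which would stay within the scatter. Compound 3 is estimated at 8500 nM, with an expected range of 3500 nM to 20000 nM.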

Compound 3, half-maximal inhibitory concentration: 5210 nM
Estimate against measurement, compound 3: 1.6-fold (0.21 log units) above, and the stated range covers the measured number.
By their numbers in this assay, from the lowest: compounds 3, 1 and 2 (each within the scatter of the next).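

At the thiocarbonyl carbon, the exchange in this assay gives a 2.0-fold lower number from compound 2 to compound 3 (0.29 log units; within the scatter), and set against the first compound it gives a 1.4-fold lower number from compound 1 to compound 3 (0.14 log units; within the scatter), so neither step separates the new group from the earlier ones. The 6-methyl-1,2,3,4-tetrahydroquinolin-1-yl group, with its six-membered non-aromatic ring and no hydrogen-bond acceptor, therefore stands level with both morpholin-4-yl and 5-methoxy-2,3-dihydro-1H-indol-1-yl, and this place has now held three different groups with no step beyond the scatter. Nothing is available that could explain this result.

From the compounds shown here alone, whether any group on the thiocarbonyl carbon can move the number beyond the scatter remains open. A diethylamino group or a piperazin-1-yl group carrying a free amine would test this.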